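From methylsulfonyl to ethoxy: expecting faster removal

A few compounds are considered here, and "the series" means these few. Any claim that something is new, unique, unknown or untested is made for them only; others in the source may bear on it.

In an in vitro ADME assay on microsomes from liver (Homo sapiens) for metabolic stability (a higher number here means faster removal of the compound, a lower number slower removal), compound 2 `CS(=O)(=O)Cc1cccc2c1CCC2c1ncc[nH]1` gives < 7 mL.min-1.g-1 as a limit of the assay and not as a number. Compound 1 `CS(=O)(=O)Nc1c(Cl)ccc2c1CCCC2c1ncc[nH]1` gives < 7 mL.min-1.g-1 and this too is a limit. Compound 3 `COCc1cccc2c1CC[C@H]2c1ncc[nH]1` gives 12 mL.min-1.g-1 as a true number. Among the measured compounds shown here, compound 4 `CCOCc1cccc2c1CCC2c1ncc[nH]1` is still unmeasured and arises from compound 2 with ethoxy in place of methylsulfonyl on a saturated chain carbon bound to an aromatic carbon as the one change ethoxy in place of methylsulfonyl on a saturated chain carbon bound to an aromatic carbon between them. Faster removal is expected in this assay because compound 3 at 12 mL.min-1.g-1 is the closest measured guide. An upward move of an at least 2.5-fold higher number from compound 2 to compound 4 (0.41 log units; beyond the scatter) is expected. Compound 4 is estimated at 18 mL.min-1.g-1 with an expected range from 8 mL.min-1.g-1 to 40 mL.min-1.g-1 in intrinsic clearance.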

Compound 4, intrinsic clearance in microsomes: 115 mL.min-1.g-1
For compound 4 the middle estimate is 6.4-fold (0.81 log units) below the measured one; the whole stated range lies below it.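

In this assay, the group carried on this saturated chain carbon bound to an aromatic carbon can matter greatly: ethoxy in place of methylsulfonyl gives an at least 16-fold higher number from compound 2 to compound 4 (1.21 log units; beyond the scatter). Compound 2 gives < 7 mL.min-1.g-1, which is a limit of the assay and not a number. The step is only a lower bound on the true change, because of where compound 2 sits: the limit of < 7 mL.min-1.g-1 in this assay, at which 2 of the 4 values shown sit.

The compounds shown cannot tell whether losing methylsulfonyl or gaining ethoxy drives this jump. An amine or a carboxylic acid at this place could help to separate the two.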